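The source may hold more compounds than are shown below. What is called first, only, known or untested is meant among the compounds shown, and "the series" means these compounds.

In a functional assay on MDA-MB-231 cells (Homo sapiens) for inhibition, read by CCK-8 assay and cell counting, with a stated time of 2 days (on this read-out higher numbers stand for weaker inhibition and lower numbers for stronger inhibition), three related compounds have been measured so far. Compound 3 (`O=C(/C=C/c1ccco1)c1ccc(OCC2CO2)cc1`) gives 47100 nM in this test. Compound 1 (`O=C(/C=C/c1ccco1)c1ccccc1OCC1CO1`) gives 28700 nM and lies within the usual scatter of compound 3, so the two cannot be told apart. Compound 2 (`O=C(/C=C/c1cccs1)c1cccc(OCC2CO2)c1`) gives 15400 nM as its result, a number lower than that of compound 3 by more than the scatter, so compound 3 inhibits less strongly than compound 2.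

Compound 4 (`O=C(/C=C/c1cccs1)c1ccc(OCC2CO2)cc1`) has not been measured yet. It differs from compound 3 in one place only, with thiophen-2-yl in place of furan-2-yl on a double-bonded chain carbon bound to a double-bonded chain carbon. Among the compounds with values here, no measured pair shows this exchange alone, so the evidence is thin. Within the data shown here, compound 2 is the only measured compound carrying thiophen-2-yl, and its 15400 nM offers a single hint, although it also differs from compound 3 elsewhere. The expected step of a 1.6-fold lower number from compound 3 to compound 4 (0.20 log units; within the scatter) is therefore small, pointing towards a lower number but not beyond the scatter. For compound 4 the estimated value is 30000 nM in this assay, with an expected range from 14000 nM to 62000 nM.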

Compound 4, half-maximal inhibitory concentration: 28300 nM
Estimate against measurement, compound 4: 1.1-fold (0.03 log units) above, and the stated range covers the measured number.
By their numbers in this assay, from the lowest: compounds 2, 4, 1 and 3 (each within the scatter of the next, the first and the last beyond it).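

Within the data shown here, compound 3 and compound 4 form the first pair here in which thiophen-2-yl replaces furan-2-yl with nothing else changed. In this assay this exchange gives a 1.7-fold lower number from compound 3 to compound 4 (0.22 log units; within the scatter) and so does not separate the two compounds at this place, on a double-bonded chain carbon bound to a double-bonded chain carbon. The two groups match in heavy-atom count, ring size and hydrogen-bond acceptor count and differ in one ring atom, sulfur for oxygen, so this pair shows that such a swap at this place leaves this assay unable to tell the compounds apart, and no separate measurement is available to explain that result.

The compounds shown do not tell whether the same exchange would also stay within the scatter on the core of compound 1, where the side chain is arranged differently. They also leave open whether a larger or differently built group at this place, such as a phenyl ring or a ring carrying an amine, would move the number beyond the scatter.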